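The source may hold more compounds than are shown below. What is called first, only, known or untested is meant among the compounds shown, and "the series" means these compounds.

Of the compounds shown here, two that share one core have been tested in a functional assay on the whole organism (strain C57BL/6) for inhibition, with Mus musculus as the target, read by microscopy, with a stated time of 6 days, at a dose of 10 mg/kg by the oral route; a lower number here means less inhibition, a higher number more inhibition at the dose given (going by the name of the read-out). Compound 1 `C[C@H]1NCc2ncnc(Oc3ccc4c(ccn4C(=O)Nc4cccc(C(F)(F)F)c4)c3)c21` gives 0% in this assay. Compound 2 `CC(C)c1cc(NC(=O)n2ccc3cc(Oc4ncnc5c4CCNC5)ccc32)n[nH]1` gives 0% in this assay, level with compound 1 at the digits reported, so the two values lie within the scatter and neither can be ranked against the other. Compound 3 `CC(C)(C)c1cc(NC(=O)n2ccc3cc(Oc4ncnc5c4CCNC5)ccc32)n[nH]1` has not yet been measured. It differs from compound 2 in a single place: methyl in place of hydrogen on a saturated chain carbon bound to an aromatic carbon and two saturated chain carbons. For the measured compounds named here, no pair of measured compounds shows what this kind of change does here, so its effect is open; with compound 2 at 0% and compound 1 at 0%, nothing in the numbers points to a move beyond the scatter in either direction. The step in this assay is expected to be a number 2 percentage points higher from compound 2 to compound 3 (within the scatter). Compound 3 is therefore expected to give 2%, within a range from 0% to 15%.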

Compound 3, a percentage reported as inhibition, in the whole organism at one dose (the size of the read-out at that dose, not a potency): 0%
The estimate for compound 3 lay 2 percentage points above the measured number; measured number inside the range.
By their numbers in this assay, from the lowest: compounds 1, 2 and 3 (each within the scatter of the next).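

Swapping isopropyl for tert-butyl, which places methyl in place of hydrogen on a saturated chain carbon bound to an aromatic carbon and two saturated chain carbons, gives the first reading of this kind of change in this assay: no change at the digits printed from compound 2 to compound 3 (within the scatter). With all three compounds reading zero, this read-out does not separate the two groups, so the result shows neither a gain nor a loss from the added methyl. No supporting measurement bears on this result.

From the compounds shown here alone, whether any group at this place can give a reading above zero at this dose remains open. A carboxylic acid, an amine or a longer chain in place of tert-butyl would each test this, and the compounds shown say nothing about them.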